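Swapping a thiophene for a chlorophenyl on a shared core

This account rests on a few compounds, and the source may have more. Where it says the series, first, only, none or still open, it means among the compounds named here.

Measured so far:
compound 1, `c1ccc(-c2cn3ccnc3c(-c3ccc4ncn(C5CCCCC5)c4c3)n2)cc1`, 27.8%
compound 2, `COc1ccc(-c2cn3ccnc3c(-c3ccc4ncn(C5CCCCC5)c4c3)n2)cc1`, -43.4%
compound 3, `c1cn2cc(-c3ccsc3)nc(-c3ccc4ncn(C5CCCCC5)c4c3)c2n1`, 6.29%

All three share one core and differ only in the aryl group attached to it. In a functional assay on SF-539 cells (Homo sapiens) for inhibition, read by sulforhodamine B assay, with a stated time of 48 h, tested at 10 uM (a lower number here means less inhibition, a higher number more inhibition at the concentration tested (going by the name of the read-out)), compound 3 stands second highest of the three numbers: compound 1 lies above it by a number 21.5 percentage points lower from compound 1 to compound 3 (beyond the scatter), and compound 2 lies below it by a number 49.7 percentage points higher from compound 2 to compound 3 (beyond the scatter). Compound 4, `Clc1ccc(-c2cn3ccnc3c(-c3ccc4ncn(C5CCCCC5)c4c3)n2)cc1`, carries the change (4-chlorophenyl in place of thiophen-3-yl on an aromatic carbon).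

For the measured compounds named here, no measured step matches this change directly. Going by the values given here, two steps bear on it. The step of a number 21.5 percentage points lower from compound 1 to compound 3 (beyond the scatter) shows that exchanging phenyl for thiophen-3-yl cost a modest amount, so returning to a six-membered carbon ring might recover some inhibition. As far as these compounds go, the step of a number 71.2 percentage points lower from compound 1 to compound 2 (beyond the scatter) shows that adding a methoxy group to phenyl cost a large amount; whether chlorine behaves the same is unknown. Weighing both, the step of a number 3.7 percentage points higher from compound 3 to compound 4 (within the scatter) is expected to be small, within the scatter. Compound 4 is therefore estimated at 10%, with a wide range from -35% to 45%.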

Compound 4, a percentage reported as inhibition, at one concentration (the size of the read-out at that concentration, not a potency): 6.3%
For compound 4 the middle estimate is 3.7 percentage points above the measured one, and the stated range covers the measured number.
By their numbers in this assay, from the lowest: compound 2; then compounds 3 and 4 (each within the scatter of the next); then compound 1.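

In this assay the step of a number 0 percentage points higher from compound 3 to compound 4 (within the scatter) shows that at this position, the 4-chlorophenyl and thiophen-3-yl groups cannot be told apart, even though one ring is six-membered and the other five-membered. The result also shows that the group added to the phenyl ring matters, as the step of a number 49.7 percentage points higher from compound 2 to compound 4 (beyond the scatter) separates chloro from methoxy, while the step of a number 21.5 percentage points lower from compound 1 to compound 4 (beyond the scatter) shows that chloro still gives a lower number than the plain phenyl of compound 1, as methoxy does. No measurement at hand explains these differences. The compounds shown leave open how a phenyl ring carrying an amine or a carboxylic acid would behave here. They also leave open whether any added group could raise the number above that of compound 1.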